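The compounds below may be only part of what the source reports. "The series", "measured", "known", "first", "only" and "open" are said of these compounds alone.

Working notes, series read in a physicochemical assay, read by spectrophotometry, with a stated time of 30 min; on this read-out lower numbers stand for stronger inhibition and higher numbers for weaker inhibition:

- compound 1 `O=C(CC(c1ccccc1)c1c[nH]c2ccccc12)c1c(O)c2ccccc2oc1=O`: 12.4 ug/mL
- compound 2 `O=C(CC(c1ccccc1Cl)c1c[nH]c2ccccc12)c1c(O)c2ccccc2oc1=O`: 39.6 ug/mL
- compound 3 `COc1ccc(C(CC(=O)c2c(O)c3ccccc3oc2=O)c2c[nH]c3ccccc23)cc1OC`: 63.2 ug/mL

Compound 2 and compound 3 share the weak end of this small set, with compound 3 at 63.2 ug/mL. The measured steps to it are a 1.6-fold higher number from compound 2 to compound 3 (0.20 log units; within the scatter) and a 5.1-fold higher number from compound 1 to compound 3 (0.71 log units; beyond the scatter).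

The next structure is compound 4 `O=C(CC(c1ccc(O)cc1)c1c[nH]c2ccccc12)c1c(O)c2ccccc2oc1=O`, with 4-hydroxyphenyl in place of 3,4-dimethoxyphenyl on a saturated chain carbon bound to an aromatic carbon and a saturated chain carbon.

Within the data shown here, two measured steps bear on this change. One is the step above that introduces the 3,4-dimethoxyphenyl group, and the other is a 3.2-fold higher number from compound 1 to compound 2 (0.50 log units; beyond the scatter). In these three compounds, both substituted phenyl groups give higher numbers than phenyl itself, and none goes against this. Among the measured compounds shown here, no hydroxyl-bearing analogue has been measured, so the evidence is indirect.

A modest step to a lower number is expected in this assay, partly undoing the rise seen from phenyl. The expected change is a 2.3-fold lower number from compound 3 to compound 4 (0.35 log units; beyond the scatter). For compound 4 the estimated value is 28 ug/mL, with an expected range of 9 ug/mL to 85 ug/mL.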

Compound 4, half-maximal inhibitory concentration: 58.9 ug/mL
For compound 4 the middle estimate is 2.1-fold (0.32 log units) below the measured one, within the range that was stated.
By their numbers in this assay, from the lowest: compound 1; then compounds 2, 4 and 3 (each within the scatter of the next).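

In this assay the hydroxyl-bearing analogue now gives a direct reading at this position: the step of a 4.8-fold higher number from compound 1 to compound 4 (0.68 log units; beyond the scatter) shows that 4-hydroxyphenyl also stands clear of the unsubstituted phenyl, and none of the three substituted phenyl groups goes against this. The other two steps, a 1.1-fold lower number from compound 3 to compound 4 (0.03 log units; within the scatter) and a 1.5-fold higher number from compound 2 to compound 4 (0.17 log units; within the scatter), lie within the scatter, so 4-hydroxyphenyl cannot be told apart from 3,4-dimethoxyphenyl or 2-chlorophenyl here, despite the different counts of hydrogen-bond donors and acceptors in 4-hydroxyphenyl and 3,4-dimethoxyphenyl. No supporting measurement is available to explain the higher numbers seen with these substituted phenyl groups.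

The compounds shown leave open whether any substituent on this phenyl can match or improve on the number of compound 1. An amine or a carboxylic acid in place of the hydroxy group would test whether the rise holds beyond these three groups.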